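Chalcone cytotoxicity in human fibroblasts: compound 2 to compound 4

This account rests on a few compounds, and the source may have more. Where it says the series, first, only, none or still open, it means among the compounds named here.

compound 1 `COc1cc(O)c(C(=O)/C=C/c2ccc(F)cc2)c(OC)c1`: > 20000 nM
compound 2 `COc1cc(OC)c(C(=O)/C=C/c2ccc(Br)cc2)c(OC)c1`: > 20000 nM
compound 3 `COc1cc(OC)c(C(=O)/C=C/c2ccc([N+](=O)[O-])cc2)c(OC)c1`: 7300 nM

In an ADME assay on cells (Fibroblast, Homo sapiens) for cytotoxicity, with a stated time of 48 h (on this read-out higher numbers stand for weaker inhibition and lower numbers for stronger inhibition), compound 1 gives only a limit, > 20000 nM. Compound 2 likewise gives only a limit, > 20000 nM. Compound 3 gives a number, 7300 nM. Among the compounds with values here, the one measured step, an at least 2.7-fold lower number from compound 2 to compound 3 (0.43 log units; beyond the scatter), shows a change on the aromatic ring moving a value off the limit. Compound 2 itself stands at the limit of > 20000 nM in this assay, at which 2 of the 3 values shown sit, so no number is known for it. Compound 4 `COc1cc(OC)c(C(=O)/C=C/c2ccccc2OC)c(OC)c1` differs from compound 2 by 2-methoxyphenyl in place of 4-bromophenyl on a double-bonded chain carbon bound to a double-bonded chain carbon. Within the data shown here, no measured step covers this particular change, and the bromo-to-nitro step does not share its groups. Compound 4 is therefore expected near 20000 nM (range 7000 nM to 60000 nM), an expected step of a number no higher from compound 2 to compound 4 (the limit leaves the size open), with a limit again likely.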

Compound 4, half-maximal inhibitory concentration: 8200 nM
Compound 4: middle estimate off by 2.4-fold (0.39 log units), on the high side, and the stated range covers the measured number.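

In this assay, 2-methoxyphenyl in place of 4-bromophenyl on a double-bonded chain carbon bound to a double-bonded chain carbon gives an at least 2.4-fold lower number from compound 2 to compound 4 (0.38 log units; beyond the scatter). Compound 2 gives only a limit, > 20000 nM. Within the data shown here, a nitro group is therefore not the only change at this aromatic ring that yields a measured number rather than a limit, though the size of this step stays open. The compounds shown do not separate the arrival of methoxy from the loss of bromo. Going by these compounds, how an amine or a carboxylic acid on this ring would read also remains open.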